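A few compounds are considered here, and "the series" means these few. Any claim that something is new, unique, unknown or untested is made for them only; others in the source may bear on it.

In an ADME assay on A549 cells (Homo sapiens) for cytotoxicity, read by resazurin assay, with a stated time of 48 h (on this read-out higher numbers stand for lower toxicity in this test and lower numbers for higher toxicity in this test), compound 1 (`O=C(Nc1ccc(NC2CCCCC2)cc1Cl)c1cc(Cl)ccc1O`) gives 68300 nM while compound 2 (`O=C(Nc1ccc(NCc2ccc(F)cc2)cc1Cl)c1cc(Cl)ccc1O`) gives 54400 nM and compound 3 (`O=C(Nc1ccc(NCc2ccc(Br)cc2)cc1Cl)c1cc(Cl)ccc1O`) gives 40900 nM on the shared core, which places compound 3 within the scatter of both others. Compound 4 (`COc1ccc(CNc2ccc(NC(=O)c3cc(Cl)ccc3O)c(Cl)c2)cc1`) has methoxy in place of bromo on an aromatic carbon, para to a large group. The steps bearing on this are bromo in place of fluoro (a 1.3-fold lower number from compound 2 to compound 3 (0.12 log units; within the scatter)) and the two changes from cyclohexyl (a 1.3-fold lower number from compound 1 to compound 2 (0.10 log units; within the scatter) and a 1.7-fold lower number from compound 1 to compound 3 (0.22 log units; within the scatter)), all small. No step beyond the scatter is therefore expected in this assay for this change. The estimated step (a 1.2-fold higher number from compound 3 to compound 4 (0.07 log units; within the scatter)) stays within the scatter. Compound 4 is estimated at 48000 nM with an expected range from 27000 nM to 85000 nM on this read-out.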

Compound 4, half-maximal cytotoxic concentration: 80700 nM
Compound 4: middle estimate off by 1.7-fold (0.23 log units), on the low side; measured number inside the range.
By their numbers in this assay, from the lowest: compounds 3, 2, 1 and 4 (each within the scatter of the next).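

In this assay, methoxy at this place, para to a large group, gives a 2.0-fold higher number from compound 3 to compound 4 (0.30 log units; within the scatter), along with a 1.5-fold higher number from compound 2 to compound 4 (0.17 log units; within the scatter) and a 1.2-fold higher number from compound 1 to compound 4 (0.07 log units; within the scatter). Among these compounds, the step from bromo is the largest so far, yet it is still printed as within the scatter, so methoxy, fluoro and bromo here cannot be told apart, and 4-methoxybenzyl cannot be told apart from cyclohexyl on the nitrogen. No measurement bears on why these steps are small. Going by these compounds, whether an amine or a carboxylic acid at this place would give a step beyond the scatter remains open.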